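The source may hold more compounds than are shown below. What is called first, only, known or untested is meant among the compounds shown, and "the series" means these compounds.

Compound 1, `Cc1nc(SCC(=O)Nc2nc(-c3ccc(Cl)cc3)cs2)n(Nc2ccccc2)c1C`, is the anchor of this account. In a functional assay on HCT-116 cells (Homo sapiens) for antiproliferative activity, read by sulforhodamine B assay, with a stated time of 48 h (a higher number here means that more compound is tolerated, a lower number that less compound is tolerated), compound 1 gives 15500 nM, and this is the only number shown. Compound 2, `Cc1ccc(Nn2c(SCC(=O)Nc3nc(-c4ccccc4)cs3)nc(C)c2C)cc1`, carries a methyl on the anilino ring and lacks the chlorine on the other aryl ring, so it differs from compound 1 in two places. In this assay compound 2 gives > 100000 nM, which is a limit of the assay and not a number; that is the limit of > 100000 nM in this assay, at which 1 of the 2 values shown sits.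

Compound 3, `COc1ccc(Nn2c(SCC(=O)Nc3nc(-c4ccc(Cl)cc4)cs3)nc(C)c2C)cc1`, differs from compound 1 by methoxy in place of hydrogen on an aromatic carbon, a methoxy in place of hydrogen on an aromatic carbon, para to a large group. For the measured compounds named here, no step between measured compounds is at hand to size this change, and the pair of compound 1 and compound 2 shows only that the former gives a number and the latter a limit. The step of a 2.6-fold higher number from compound 1 to compound 3 (0.41 log units; beyond the scatter) is expected to go upward, toward more compound tolerated, beyond the scatter, with a fair chance of ending at the limit. Compound 3 is thus estimated at 40000 nM, between 12000 nM and 130000 nM.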

Compound 3, concentration lethal to 50% of the cells: > 100000 nM
Compound 3 was reported as a limit (the forecaster's own chance of this, stated with the estimate: 40%); middle value at least 2.5-fold (0.39 log units) from the limit.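

With methoxy in place of hydrogen on an aromatic carbon, para to a large group, the anilino ring of compound 1 now has a change in one place whose direction can be read, which the two-place difference of compound 2 did not allow: in this assay the result is an at least 6.4-fold higher number from compound 1 to compound 3 (0.80 log units; beyond the scatter). Compound 3 gives > 100000 nM, which is a limit of the assay and not a number. The full size of the step stays unknown because compound 3 stands at this limit, so the 4-methoxyphenyl group is shown only to lie on the side of more compound tolerated, beyond the scatter: the limit of > 100000 nM in this assay, at which 2 of the 3 values shown sit.

As far as these compounds go, it remains open whether a smaller group at the same place, such as a fluorine or a hydroxyl, would keep a number in this assay or would also reach the limit. From the compounds shown here alone, it is equally open whether a methoxy on another carbon of this ring, or an amine at the place where it sits in compound 3, would give the same direction of change.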